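This account rests on a few compounds, and the source may have more. Where it says the series, first, only, none or still open, it means among the compounds named here.

Measured so far in a functional assay on SGC-7901 cells (Homo sapiens) for antiproliferative activity, read by MTT assay, with a stated time of 72 h; a higher number here means a weaker inhibitor, a lower number a stronger inhibitor:
Compound 1, `COc1cc(-n2cnc3ccc(-c4cc(F)ccc4F)cc32)cc(OC)c1OC`, gives 6590 nM.
Compound 2, `COc1cc(-n2cnc3ccc(-c4ccc(C(F)(F)F)cc4)cc32)cc(OC)c1OC`, gives 890 nM.
Compound 3, `COc1cc(-n2cnc3ccc(-c4cccc(Cl)c4)cc32)cc(OC)c1OC`, gives 1490 nM.

Compound 1 has the highest number of the three and is therefore the weakest inhibitor among them: compound 3 sits nearest, a 4.4-fold lower number from compound 1 to compound 3 (0.65 log units; beyond the scatter), and compound 2 furthest, a 7.4-fold lower number from compound 1 to compound 2 (0.87 log units; beyond the scatter). Compound 4, `COc1cc(-n2cnc3ccc(-c4ccc(Cl)cc4)cc32)cc(OC)c1OC`, has not yet been measured. It differs from compound 1 in one place: 4-chlorophenyl in place of 2,5-difluorophenyl on an aromatic carbon. Both known steps away from compound 1 bear on this change, since each also replaces the 2,5-difluorophenyl with a phenyl carrying a single group, and each lowered the number beyond the scatter by a modest amount. Between compound 2 and compound 3 the gap is small, a 1.7-fold higher number from compound 2 to compound 3 (0.22 log units; within the scatter), so which single group sits on the phenyl seems to matter less than leaving the 2,5-difluorophenyl behind. A downward step of similar size is therefore expected for compound 4 in this assay, namely a 6.0-fold lower number from compound 1 to compound 4 (0.78 log units; beyond the scatter). Compound 4 is estimated at 1100 nM, within a range from 400 nM to 3000 nM.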

Compound 4, half-maximal inhibitory concentration: 1270 nM
Estimate against measurement, compound 4: 1.2-fold (0.06 log units) below; measured number inside the range.
By their numbers in this assay, from the lowest: compounds 2, 4 and 3 (each within the scatter of the next); then compound 1.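

In this assay, moving the chlorine from the 3-chlorophenyl of compound 3 to the 4-chlorophenyl of compound 4 gives no readable change (a 1.2-fold lower number from compound 3 to compound 4 (0.07 log units; within the scatter)), so among these two compounds the place of the chloro on this phenyl does not show in the number. Among these compounds, exchanging trifluoromethyl for chloro with the place held fixed also stays within the scatter (a 1.4-fold higher number from compound 2 to compound 4 (0.15 log units; within the scatter)), which is the first comparison of two groups at the same place on this phenyl. Compound 4 still stands clearly apart from the 2,5-difluorophenyl compound (a 5.2-fold lower number from compound 1 to compound 4 (0.72 log units; beyond the scatter)), leaving compound 1 alone among the four.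

No measurement shown gives a reason for this gap. Still open, from the compounds shown here alone, is whether a plain phenyl, or a phenyl carrying an amine, a carboxylic acid or a methoxy group, would fall with compounds 2, 3 and 4 or with compound 1.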